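A few compounds are considered here, and "the series" means these few. Any claim that something is new, unique, unknown or untested is made for them only; others in the source may bear on it.

Working notes on the series. All three measured compounds share one core and differ only at the amine. Compound 1 `CC(=O)Nc1ccc([C@H](C)NCC2CCN(CCCc3c[nH]c4ccc(-n5cnnc5)cc34)CC2)cc1` carries a 1-(4-acetamidophenyl)ethyl group there and in an assay on CHO cells for displacement of a labelled ligand from 5-hydroxytryptamine receptor 1D (Homo sapiens) (a higher number here means a weaker inhibitor, a lower number a stronger inhibitor), compound 1 gives 0.6 nM. Compound 2 `C[C@H](NCC1CCN(CCCc2c[nH]c3ccc(-n4cnnc4)cc23)CC1)c1ccccc1` gives 4.4 nM in this assay, and compound 3 `c1ccc(NCC2CCN(CCCc3c[nH]c4ccc(-n5cnnc5)cc34)CC2)nc1` gives 1.7 nM. Compound 3 thus stands second highest of the three numbers: a 2.8-fold higher number from compound 1 to compound 3 (0.45 log units; beyond the scatter), while a 2.6-fold lower number from compound 2 to compound 3 (0.41 log units; beyond the scatter). The remaining step, a 7.3-fold higher number from compound 1 to compound 2 (0.87 log units; beyond the scatter), shows that loss of the acetamido group weakens binding.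

Compound 4 `CC(=O)Nc1ccc(CNCC2CCN(CCCc3c[nH]c4ccc(-n5cnnc5)cc34)CC2)cc1` is not yet measured. Its change from compound 3 is 4-acetamidobenzyl in place of pyridin-2-yl on an amine nitrogen; compound 4 therefore differs from compound 1 only in lacking the methyl of the 1-(4-acetamidophenyl)ethyl group. The step that bears most directly is a 2.8-fold higher number from compound 1 to compound 3 (0.45 log units; beyond the scatter), which compound 4 should largely reverse, with a 7.3-fold higher number from compound 1 to compound 2 (0.87 log units; beyond the scatter) showing the acetamido group is worth keeping. The expected step is a 2.1-fold lower number from compound 3 to compound 4 (0.33 log units; beyond the scatter). Compound 4 is estimated at 0.8 nM, with a range of 0.3 nM to 2.5 nM.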

Compound 4, half-maximal inhibitory concentration: 4.2 nM
The estimate for compound 4 lay 5.3-fold (0.72 log units) below the measured number; the whole stated range lies below it.
By their numbers in this assay, from the lowest: compound 1; then compound 3; then compounds 4 and 2 (each within the scatter of the next).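

Taking the methyl off the saturated chain carbon bound to the amine nitrogen costs as much as a step can in this set (a 7.0-fold higher number from compound 1 to compound 4 (0.85 log units; beyond the scatter)), so the acetamido group alone does not keep the low number of compound 1. The 4-acetamidobenzyl group also does not improve on pyridin-2-yl on the amine nitrogen (a 2.5-fold higher number from compound 3 to compound 4 (0.39 log units; beyond the scatter)), so a larger group carrying the acetamido offers no gain at this position. It stands level with 1-phenylethyl (a 1.0-fold lower number from compound 2 to compound 4 (0.02 log units; within the scatter)), so among these compounds only the group with both the methyl and the acetamido, in compound 1, reaches the lowest number.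

Going by these compounds, how an unsubstituted benzyl on the amine nitrogen, or an ethyl in place of the methyl, would compare remains open. Nothing at hand accounts for these steps.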